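Notes on a small series of adenosine antagonists

This account rests on a few compounds, and the source may have more. Where it says the series, first, only, none or still open, it means among the compounds named here.

Measured so far:
compound 1, `CC(C)(C)OC(=O)NCCNc1nc(N)n2nc(-c3ccco3)nc2n1`: in a functional assay on CHO cells for antagonist activity at adenosine receptor A2b (Homo sapiens) (a higher number here means a weaker inhibitor, a lower number a stronger inhibitor), compound 1 gives > 10000 nM, a limit of the assay rather than a number.
compound 2, `CCCCC(=O)N1CCN(c2nc(N)n3nc(-c4ccco4)nc3n2)CC1`: in this assay compound 2 gives > 100000 nM, likewise a limit of the assay.

Both values shown are limits (the limit of > 10000 nM in this assay, at which 1 of the 2 values shown sits, (the limit of > 100000 nM in this assay, at which 1 of the 2 values shown sits)), so compound 2 stands at the limit > 100000 nM and no order between the two measured compounds can be read. Compound 3, `Nc1nc(N2CCN(C(=O)C(Cl)Cl)CC2)nc2nc(-c3ccco3)nn12`, differs from compound 2 by dichloromethyl in place of butyl on a carbonyl carbon. Among the compounds with values here, no measured step links two compounds here, so no direction in this assay is given; a change within the usual scatter is expected, most likely ending again at a limit. Compound 3 is estimated at 60000 nM, range 5000 nM to 300000 nM, which means an expected step of an at least 1.6-fold lower number from compound 2 to compound 3 (0.22 log units; that floor lies within the scatter).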

Compound 3, half-maximal inhibitory concentration: > 100000 nM
Compound 3 ended at the assay's limit; the forecaster's own chance of this, stated with the estimate: 70%; middle value at least 1.6-fold (0.22 log units) from the limit.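

Within the data shown here, compound 2 and compound 3 both stand at a limit in this assay, so no step between them can be read. The compounds shown leave open what number, if any, either substituent on the carbonyl carbon would give within the assay's range.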